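Methylamino for tert-butoxy: notes on the series

The source may report more compounds than this note shows. Statements on the series, on what has been measured and on what is new or still open speak of the compounds shown alone.

Measured so far in an ADME assay on L6 cells (Rattus norvegicus) for cytotoxicity, read by resazurin assay, with a stated time of 72 h; on this read-out lower numbers stand for an effect already at smaller amounts and higher numbers for an effect only at larger amounts of compound
- compound 1 `CCOC(=O)C1=C(C)N/C(=C/c2c(C)nn(-c3ccccc3)c2Cl)C1=O` gives 13000 nM
- compound 2 `CC1=C(C(=O)OC(C)(C)C)C(=O)/C(=C\c2cc(C)n(-c3ccccc3C(F)(F)F)c2C)N1` gives 110000 nM

Compound 2 at 110000 nM stands highest of these two numbers, and the gap down to compound 1 lies beyond the scatter. Compound 3 `CNC(=O)C1=C(C)N/C(=C/c2cc(C)n(-c3ccccc3C(F)(F)F)c2C)C1=O` differs from compound 2 in one place, with methylamino in place of tert-butoxy on a carbonyl carbon. Among the compounds with values here, compound 1 and compound 2 differ in more than one place, so no measured pair shows this change on its own. The expectation in this assay therefore rests on compound 2 alone and is for no change beyond the scatter, with a slight lean to a lower number. The estimated step of a 1.3-fold lower number from compound 2 to compound 3 (0.11 log units; within the scatter) is small, and its uncertainty is wide. For compound 3 the expected value is 85000 nM (estimated range 28000 nM to 250000 nM).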

Compound 3, half-maximal effective concentration: 40000 nM
Beside the measured number, compound 3's estimate is 2.1-fold (0.33 log units) above it, and the stated range covers the measured number.
By their numbers in this assay, from the lowest: compound 1; then compound 3; then compound 2.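

In this assay the carbonyl carbon turns out to be a position that can move the number: methylamino in place of tert-butoxy gives a 2.8-fold lower number from compound 2 to compound 3 (0.44 log units; beyond the scatter) with the rest of the compound unchanged. Within the data shown here, this is the first reading of the position on its own, as compound 1 and compound 2 differ in more than one place. The change is not a single variable, since the heavy-atom count falls, a hydrogen-bond donor enters and a hydrogen-bond acceptor leaves, and no measurement here bears on which of these matters.

As far as these compounds go, whether a carboxylic acid, a dimethylamino group or a longer chain on the amide nitrogen would carry the number further in the same direction stays open. Also open, from the compounds shown here alone, is whether the same change gives a step of similar size on the core of compound 1.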